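From isopropoxy to bromo: an expected step

The compounds below may be only part of what the source reports. "The series", "measured", "known", "first", "only" and "open" are said of these compounds alone.

- compound 1 `COc1ccc(-c2cncnc2-c2cc(OC)c(OC)c(OC)c2)cc1O`: 280 nM
- compound 2 `COc1cc(-c2ncncc2-c2ccc(OC(C)C)cc2)cc(OC)c1OC`: 8360 nM

In a functional assay on HeLa cells (Homo sapiens) for antiproliferative activity, read by CCK-8 assay, with a stated time of 72 h (on this read-out lower numbers stand for stronger inhibition and higher numbers for weaker inhibition), compound 2 gives 8360 nM as the higher of the two numbers, and compound 1 gives 280 nM as the lower, a gap beyond the usual scatter. Compound 3 `COc1cc(-c2ncncc2-c2ccc(Br)cc2)cc(OC)c1OC` has not yet been measured. It differs from compound 2 in one place (bromo in place of isopropoxy on an aromatic carbon): bromo in place of isopropoxy on an aromatic carbon, para to a large group. For the measured compounds named here, no measured pair shows what this swap does, so any expectation is loose. Compound 1 at 280 nM shows that much lower numbers occur in this small set, which makes a lower number the likelier direction. The expected step is a 4.2-fold lower number from compound 2 to compound 3 (0.62 log units; beyond the scatter) and would lie beyond the scatter, toward stronger inhibition. Compound 3 is estimated at 2000 nM (expected range 400 nM to 9000 nM).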

Compound 3, half-maximal inhibitory concentration: 500 nM
Beside the measured number, compound 3's estimate is 4.0-fold (0.60 log units) above it; measured number inside the range.
By their numbers in this assay, from the lowest: compounds 1 and 3 (each within the scatter of the next); then compound 2.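

In this assay the position on this aromatic carbon proves highly sensitive to what it carries: bromo in place of isopropoxy gives a large step toward stronger inhibition (a 17-fold lower number from compound 2 to compound 3 (1.22 log units; beyond the scatter)). The group that leaves has four heavy atoms and the one that enters has one, so in this pair the larger group is not needed for activity. Exchanging the whole ring, 4-bromophenyl in place of 3-hydroxy-4-methoxyphenyl, gives no difference that can be told from the scatter (a 1.8-fold higher number from compound 1 to compound 3 (0.25 log units; within the scatter)), so these two rings cannot be ranked here.

Nothing shown gives a measured reason for the size of the bromo step. On these data alone, whether chloro, methyl or an amine on the same carbon would behave like bromo or like isopropoxy remains open.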